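Chloro pattern on the aryl piperazine arm: working notes

The compounds below may be only part of what the source reports. "The series", "measured", "known", "first", "only" and "open" are said of these compounds alone.

Measured compounds:
compound 1 `CCC1(CCCCN2CCN(c3ccc(Cl)c(Cl)c3)CC2)C(=O)Nc2ccccc21`: "not determined" (no result reported) in a functional assay on the whole organism (strain NMRI) with Mus musculus as the target, with a stated time of 5 min; on this read-out higher numbers stand for an effect only at larger amounts of compound and lower numbers for an effect already at smaller amounts
compound 2 `CCC1(CCCN2CCN(c3cccc(Cl)c3)CC2)C(=O)Nc2ccccc21`: 3 mg/kg

Compound 1 stands on no number in this assay; its result has not been determined, so it gives no anchor of its own. The only figure in the series belongs to compound 2, which in this assay gives 3 mg/kg. For the measured compounds named here, compound 2 and compound 1 differ in more than one place, and no step between them is available, so nothing is read across from that pair.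

Compound 3 `CCC1(CCCCN2CCN(c3ccc(Cl)cc3)CC2)C(=O)Nc2ccccc21` is the unmeasured target. It differs from compound 1 by hydrogen in place of chloro on an aromatic carbon. Cut one bond further out, the change reads 3,4-dichlorophenyl to 4-chlorophenyl. Going by the values given here, with no measured pair to set the size of a step in this assay, no direction is assigned to it beyond the scatter, and the expectation is that the step stays within the usual spread of repeat measurements.

For compound 3 the expected minimum effective dose in this assay is 3 mg/kg, estimated to lie between 1 mg/kg and 10 mg/kg.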

Compound 3, minimum effective dose: > 10 mg/kg
Compound 3 gave a limit, no number (the forecaster's own chance of this, stated with the estimate: 15%); middle value at least 3.3-fold (0.52 log units) away from the limit.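

In this assay compound 3 gives > 10 mg/kg, which is a limit and not a number. For the compounds shown here, compound 1 offers no number either, and no step from compound 1 to compound 3 can be read. The compounds shown leave open whether going from 3,4-dichlorophenyl to 4-chlorophenyl changes the minimum effective dose at all.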